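Replacing the Carboxy End of a Side Chain

This account rests on a few compounds, and the source may have more. Where it says the series, first, only, none or still open, it means among the compounds named here.

In a functional assay on TSGH cells (Homo sapiens) for inhibition, with a stated time of 72 h (on this read-out higher numbers stand for weaker inhibition and lower numbers for stronger inhibition), compound 1 `COc1cc(C(=O)c2ccc3[nH]ccc3c2)cc(OC)c1OC` gives 103 nM, compound 2 `COc1cc(C(=O)c2ccc3c(ccn3C)c2)cc(OC)c1OC` gives 13.4 nM, and compound 3 `COc1cc(C(=O)c2ccc3c(ccn3CC(=O)O)c2)cc(OC)c1OC` gives 548 nM, the highest number of the three and so the weakest inhibition. Compound 4 `COc1cc(C(=O)c2ccc3c(ccn3CCN(C)C)c2)cc(OC)c1OC` is not yet measured. The change is (dimethylamino)methyl in place of carboxy on a saturated chain carbon bound to an aromatic nitrogen. The closest guide is the large step of a 41-fold higher number from compound 2 to compound 3 (1.61 log units; beyond the scatter), where carboxy arrived. Two modest steps also bear on this nitrogen: a 7.7-fold lower number from compound 1 to compound 2 (0.89 log units; beyond the scatter) and a 5.3-fold higher number from compound 1 to compound 3 (0.73 log units; beyond the scatter). No chain ending in an amine has been measured, so this guide is only partial. Losing the carboxy should recover part of that large step, and the expected change is a 9.1-fold lower number from compound 3 to compound 4 (0.96 log units; beyond the scatter). Compound 4 is estimated at 60 nM, within a range of 15 nM to 250 nM.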

Compound 4, half-maximal inhibitory concentration: 4900 nM
Compound 4: middle estimate off by 82-fold (1.91 log units), on the low side; the measured number lies above the stated range.
By their numbers in this assay, from the lowest: compound 2; then compound 1; then compound 3; then compound 4.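

In this assay, the step of an 8.9-fold higher number from compound 3 to compound 4 (0.95 log units; beyond the scatter) shows that removing the carboxy recovers nothing here: the amine-ended chain inhibits even less. With a 370-fold higher number from compound 2 to compound 4 (2.56 log units; beyond the scatter) and a 48-fold higher number from compound 1 to compound 4 (1.68 log units; beyond the scatter) as well, compound 4 is the weakest of the four, so at this aromatic nitrogen, a carboxy-free chain end does not by itself bring back strong inhibition. No measured evidence explains this result.

From the compounds shown here alone, whether the amine or the length of the chain matters more remains open. A 2-hydroxyethyl chain, with a hydroxyl ending, or a longer 3-(dimethylamino)propyl chain could help separate the two.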